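From methoxy to nitro on compound 1

This account rests on a few compounds, and the source may have more. Where it says the series, first, only, none or still open, it means among the compounds named here.

The compounds measured in an ADME assay on TERT-RPE1 cells (Homo sapiens) for cytotoxicity, read by MTT assay, with a stated time of 72 h (on this read-out lower numbers stand for stronger inhibition and higher numbers for weaker inhibition), are these:

Compound 1 `COc1ccc(/C=C2/CN(C)/C(=N/c3ccc(OC)cc3)S2)cc1` gives 65900 nM
Compound 2 `FC(F)(F)c1cc(/N=C2/NC/C(=C/c3ccccc3)S2)cc(C(F)(F)F)c1` gives 32800 nM
Compound 3 `S=C(Nc1ccccc1)N1C/C(=C/c2ccccc2)S/C1=N\c1ccccc1` gives > 100000 nM as a limit

In this assay the numbers for compound 1 and compound 2 lie within the usual scatter of each other, so they do not separate the two compounds. Compound 3 returned a limit and not a number, so it cannot be placed exactly against them.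

Compound 4 `COc1ccc(/C=C2/CN(C)/C(=N/c3ccc([N+](=O)[O-])cc3)S2)cc1` has not yet been measured. It keeps the core of compound 1 and differs from it in one place. The change nitro in place of methoxy on an aromatic carbon puts nitro in place of methoxy on an aromatic carbon, para to a large group.

Among the compounds with values here, no two measured compounds differ in one place, so the data offer no direct guide to this swap. The expectation rests only on the level of compound 1 at 65900 nM and compound 2 at 32800 nM in this assay and anticipates no shift beyond the scatter in either direction. The expected step is a 1.3-fold lower number from compound 1 to compound 4 (0.12 log units; within the scatter) and stays within that scatter. For compound 4 the estimated value is 50000 nM with an expected range from 15000 nM to 100000 nM.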

Compound 4, half-maximal inhibitory concentration: > 100000 nM
Compound 4: only a limit was reported; the forecaster's own chance of this, stated with the estimate: 25%; middle value at least 2.0-fold (0.30 log units) from the limit.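

Nitro in place of methoxy on an aromatic carbon, para to a large group, gives the first step that can be read in this assay: an at least 1.5-fold higher number from compound 1 to compound 4 (0.18 log units; that floor lies within the scatter). The value of compound 4 is a limit and not a number, so this step gives only a floor, and that floor does not by itself separate the two compounds. What the earlier compounds did not show is that this position can take nitro in place of methoxy with no sign of a lower number, though the read-out allows no finer statement for compound 4: the limit of > 100000 nM in this assay, at which 2 of the 4 values shown sit.

How far compound 4 actually lies from compound 1 remains open, and only methoxy and nitro are shown at this position on the core of compound 1. As far as these compounds go, whether an amine or a carboxylic acid on that aromatic carbon, or a longer chain in place of methoxy, would give a number that can be read against compound 1 also remains open.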